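A few compounds are considered here, and "the series" means these few. Any claim that something is new, unique, unknown or untested is made for them only; others in the source may bear on it.

In a functional assay on HEK293 cells for positive allosteric modulation of metabotropic glutamate receptor 5 (Rattus norvegicus), read by fluorescence and calcium flux (a higher number here means a larger maximal response, a lower number a smaller maximal response), compound 1 `CC(C)[C@H](C)NC(=O)c1ccc(C#Cc2cccc(F)c2)cn1` gives 66.7%. Compound 2 `CC(C)(C)CNC(=O)c1ccc(C#Cc2cccc(F)c2)cn1` gives 63.9%. Compound 3 `CC(C)(CO)NC(=O)c1ccc(C#Cc2cccc(F)c2)cn1` gives 60.9%.

Compound 3 thus has the lowest of the three numbers, yet the steps to it, a number 5.8 percentage points lower from compound 1 to compound 3 (within the scatter) and a number 3 percentage points lower from compound 2 to compound 3 (within the scatter), both sit within the scatter, as does a number 2.8 percentage points lower from compound 1 to compound 2 (within the scatter). All three measured compounds share one core and differ only in the group on the amide-type nitrogen, and none of those swaps moved the maximal response beyond the scatter. Compound 4 `CC1(CNC(=O)c2ccc(C#Cc3cccc(F)c3)cn2)COC1` continues this series: (3-methyloxetan-3-yl)methyl in place of 1-(hydroxymethyl)-1-methylethyl on an amide-type nitrogen. Since every earlier swap at this position left the number essentially unchanged, the step of a number 0.1 percentage points higher from compound 3 to compound 4 (within the scatter) is expected to stay within the scatter as well. Compound 4 is therefore estimated to give 61%, between 50% and 72%.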

Compound 4, largest response reached (reported as efficacy), in percent of the reference or control that the assay uses: 60.4%
Compound 4: middle estimate off by 0.6 percentage points, on the high side, and the stated range covers the measured number.
By their numbers in this assay, from the lowest: compounds 4, 3, 2 and 1 (each within the scatter of the next).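

In this assay the group on the amide-type nitrogen can also carry a ring: (3-methyloxetan-3-yl)methyl removes the hydrogen-bond donor of compound 3, yet the result is a number 0.5 percentage points lower from compound 3 to compound 4 (within the scatter) overall. Set against the groups without oxygen, the swap gives a number 3.5 percentage points lower from compound 2 to compound 4 (within the scatter) and a number 6.3 percentage points lower from compound 1 to compound 4 (within the scatter) as well. Nothing available explains this flat response.

Still open, from the compounds shown here alone, is whether an amine, a carboxylic acid or a longer chain on this nitrogen would shift the maximal response beyond the scatter. Going by these compounds, all four compounds share one core, so how these groups behave on another core also remains unknown.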